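A few compounds are considered here, and "the series" means these few. Any claim that something is new, unique, unknown or untested is made for them only; others in the source may bear on it.

Going by the values given here, compound 3 `CCn1c(C(=O)NCCN)ccc1C(CC)(CC)c1ccc(OCS(=O)(=O)c2ccccc2)c(C)c1` is the only member of the set with a number in a functional assay on BXPC-3 cells (Homo sapiens) for antiproliferative activity, read by MTT assay, with a stated time of 24 h; a lower number here means a stronger inhibitor, a higher number a weaker inhibitor: in this assay compound 3 gives 6430 nM. Compound 1 `CCn1c(C(=O)N[C@@H](CC(=O)OC)C(=O)OC)ccc1C(CC)(CC)c1ccc(OCS(=O)(=O)c2ccccc2)c(C)c1` reaches only the limit of the assay, > 50000 nM. Compound 2 `CCn1c(C(=O)NCCNC(=O)OC(C)(C)C)ccc1C(CC)(CC)c1ccc(OCS(=O)(=O)c2ccccc2)c(C)c1` likewise sits at the limit, > 50000 nM, so that the limit of > 50000 nM in this assay, at which 2 of the 3 values shown sit, holds for two of the three values. Among the compounds with values here, the steps of an at least 7.7-fold lower number from compound 1 to compound 3 (0.89 log units; beyond the scatter) and an at least 7.7-fold lower number from compound 2 to compound 3 (0.89 log units; beyond the scatter) both end at compound 3, the one compound carrying a 2-aminoethyl group. Compound 4 `CCn1c(C(=O)NCCCO)ccc1C(CC)(CC)c1ccc(OCS(=O)(=O)c2ccccc2)c(C)c1` differs from compound 3 by hydroxymethyl in place of amino on a saturated chain carbon, two bonds along the chain from an amide-type nitrogen. Because the two measured steps of an at least 7.7-fold lower number from compound 1 to compound 3 (0.89 log units; beyond the scatter) and an at least 7.7-fold lower number from compound 2 to compound 3 (0.89 log units; beyond the scatter) both favour the 2-aminoethyl compound, a rise in number toward the limit is expected for compound 4. Compound 4 is therefore estimated at 30000 nM, within 8000 nM to 100000 nM, an expected step of a 4.7-fold higher number from compound 3 to compound 4 (0.67 log units; beyond the scatter).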

Compound 4, half-maximal inhibitory concentration: 26600 nM
Beside the measured number, compound 4's estimate is 1.1-fold (0.05 log units) above it, within the range that was stated.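

In this assay, 3-hydroxypropyl in place of 2-aminoethyl gives a 4.1-fold higher number from compound 3 to compound 4 (0.62 log units; beyond the scatter), so a chain ending in hydroxyl still gives a number at this position, but the chain ending in amino keeps the lower one. Against the other two compounds, the readings are an at least 1.8-fold lower number from compound 2 to compound 4 (0.27 log units; that floor lies within the scatter) and an at least 1.8-fold lower number from compound 1 to compound 4 (0.27 log units; that floor lies within the scatter), and neither floor separates them firmly. Both floors rest on a limit: the limit of > 50000 nM in this assay, at which 2 of the 4 values shown sit.

A 2-hydroxyethyl or 3-aminopropyl chain would separate the effect of the end group from that of chain length. As far as these compounds go, how a carboxylic acid at the chain end would read stays open.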